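From Bromo to Trifluoromethoxy at the Assay Limit

A few compounds are considered here, and "the series" means these few. Any claim that something is new, unique, unknown or untested is made for them only; others in the source may bear on it.

The compounds measured so far in a functional assay on MCF cells (Homo sapiens) for antiproliferative activity, with a stated time of 72 h (a lower number here means a stronger inhibitor, a higher number a weaker inhibitor), are these:
compound 1 `OC[C@H]1O[C@@H](n2cnc3c(NCc4ccc(F)cc4)ncnc32)[C@H](O)[C@@H]1O` gives 21000 nM
compound 2 `OC[C@H]1O[C@@H](n2cnc3c(NCc4ccccc4Cl)ncnc32)[C@H](O)[C@@H]1O` gives > 166000 nM (a limit)
compound 3 `OC[C@H]1O[C@@H](n2cnc3c(NCc4ccc(Br)cc4)ncnc32)[C@H](O)[C@@H]1O` gives > 166000 nM (a limit)

For compound 3 the entry > 166000 nM is a limit and not a number. At the limit of > 166000 nM in this assay, at which 2 of the 3 values shown sit, stand compound 2 and compound 3 alike, and only compound 1 gives a true number.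

Compound 4 `OC[C@H]1O[C@@H](n2cnc3c(NCc4ccc(OC(F)(F)F)cc4)ncnc32)[C@H](O)[C@@H]1O` differs from compound 3 by trifluoromethoxy in place of bromo on an aromatic carbon and the rest of the structure stays the same.

The closest measured change also swaps one group for another on an aromatic carbon: an at least 7.9-fold higher number from compound 1 to compound 3 (0.89 log units; beyond the scatter) is beyond the scatter, but its size is only a bound. The other step from compound 1 is similar: an at least 7.9-fold higher number from compound 1 to compound 2 (0.89 log units; beyond the scatter) is likewise a bound. The last, a step that the two limits leave unreadable from compound 2 to compound 3 gives no size at all.

Going by an at least 7.9-fold higher number from compound 1 to compound 3 (0.89 log units; beyond the scatter) as the nearest guide, compound 4 is expected to stay weak, and it may well return only a limit in this assay again. If it gives a number, that number is expected to lie modestly under the limit of compound 3. The expected move is an at least 1.6-fold lower number from compound 3 to compound 4 (0.22 log units; that floor lies within the scatter) and it remains a rough estimate. For compound 4 the estimated value is 100000 nM with an expected range from 25000 nM to 200000 nM in this reading.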

Compound 4, half-maximal inhibitory concentration: > 166000 nM
Compound 4 ended at the assay's limit; the forecaster's own chance of this, stated with the estimate: 55%; middle value at least 1.6-fold (0.22 log units) from the limit.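

In this assay compound 4 gives > 166000 nM, which is a limit and not a number. Putting trifluoromethoxy in place of fluoro on the aromatic carbon para to a large group gives an at least 7.9-fold higher number from compound 1 to compound 4 (0.89 log units; beyond the scatter), so a second group at this place, after bromo, now shows a loss beyond the scatter, though the size of that loss is only a bound. Among the compounds shown here, at this place fluoro in compound 1 remains the only group with a true number, while bromo in compound 3 and trifluoromethoxy in compound 4 both end at the limit, as does compound 2, which carries its chloro at another place on the ring: the limit of > 166000 nM in this assay, at which 3 of the 4 values shown sit.

For the compounds shown here, the steps between two limits, including the one between compound 3 and compound 4, cannot be read, so it stays open whether bromo and trifluoromethoxy differ in this assay at all. On these data alone, it also stays open whether a smaller or differently built group at this place, such as a methoxy, an amine or a plain hydrogen, would give a true number as fluoro does.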